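Adding an ethyl group to the chain of compound 1

The source may report more compounds than this note shows. Statements on the series, on what has been measured and on what is new or still open speak of the compounds shown alone.

Measured in a physicochemical assay for solubility, measured as octanol-water partition, at pH 7.4; a higher number here means a more soluble compound, a lower number a less soluble compound:
Compound 1 `Nc1cc(OCCNc2ccnc3cc(Cl)ccc23)nc(N)n1` gives 1840 nM (measured)
Compound 2 `Nc1cc(OCCCNc2ccnc3cc(Cl)ccc23)nc(N)n1` gives 1200 nM (measured)
Compound 3 `Nc1cc(OCCOCCNc2ccnc3cc(Cl)ccc23)nc(N)n1` gives 440 nM (measured)

Compound 1 stands level with compound 2 within the usual scatter, while compound 3 lies lower than compound 1 by more than the scatter. No two of the three are linked by a change in one place alone. Compound 4 `CCC(COc1cc(N)nc(N)n1)Nc1ccnc2cc(Cl)ccc12` has not yet been measured. Set against compound 1, it shows the change (ethyl in place of hydrogen on a saturated chain carbon bound to a nitrogen on an aromatic ring and a saturated chain carbon), which is ethyl in place of hydrogen on a saturated chain carbon bound to a nitrogen on an aromatic ring and a saturated chain carbon. For the measured compounds named here, no measured step shows what this change does in this assay, so the guide is loose. Going by the values given here, compound 3 at 440 nM shows only that a compound with a different chain can read well under compound 1. A moderate downward step is expected, estimated as a 2.3-fold lower number from compound 1 to compound 4 (0.36 log units; beyond the scatter), though the data cannot fix its size. Compound 4 is expected at 800 nM (estimated range 280 nM to 1900 nM).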

Compound 4, solubility: 5680 nM
Compound 4: the middle estimate sits 7.1-fold (0.85 log units) below what was measured; the whole stated range lies below it.
By their numbers in this assay, from the lowest: compound 3; then compounds 2 and 1 (each within the scatter of the next); then compound 4.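

In this assay, ethyl in place of hydrogen on a saturated chain carbon bound to a nitrogen on an aromatic ring and a saturated chain carbon gives a 3.1-fold higher number from compound 1 to compound 4 (0.49 log units; beyond the scatter). This is the first step shown in which a single change can be read on its own, and it shows that this carbon carries ethyl with the number going up, not down. No measurement shown accounts for the rise.

From the compounds shown here alone, it remains open whether a rise of this kind is particular to ethyl, or whether methyl, a longer chain such as butyl, an amine or a carboxylic acid on the same carbon would move the number the same way. A single step also cannot show whether the same change would act alike on another chain.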